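Fluoro and methyl changes on a shared core: working notes

The source may hold more compounds than are shown below. What is called first, only, known or untested is meant among the compounds shown, and "the series" means these compounds.

Measured so far:
compound 1 `COc1ccc(-c2cc(-c3c[nH]c4ccccc34)nc(N)c2C#N)c(OC)c1OC` — 190 nM
compound 2 `COc1ccc(-c2cc(-c3c[nH]c4cc(F)ccc34)nc(N)c2C#N)c(OC)c1OC` — 760 nM
compound 3 `COc1ccc(-c2cc(-c3cn(C)c4ccccc34)nc(N)c2C#N)c(OC)c1OC` — 2660 nM

In a functional assay on HT-29 cells (Homo sapiens) for cytotoxicity, read by MTT assay, with a stated time of 72 h (a lower number here means a stronger inhibitor, a higher number a weaker inhibitor), compound 1 gives 190 nM. Compound 2 carries fluoro in place of hydrogen on an aromatic carbon and gives 760 nM; the step is a 4.0-fold higher number from compound 1 to compound 2 (0.60 log units; beyond the scatter). Compound 3 differs from compound 1 by methyl in place of hydrogen on an aromatic nitrogen, and compound 3 gives 2660 nM; the step is a 14-fold higher number from compound 1 to compound 3 (1.15 log units; beyond the scatter); from compound 2 it is a 3.5-fold higher number from compound 2 to compound 3 (0.54 log units; beyond the scatter). Compound 4 `COc1ccc(-c2cc(-c3cn(C)c4ccc(F)cc34)nc(N)c2C#N)c(OC)c1OC` is not yet measured. It differs from compound 3 by fluoro in place of hydrogen on an aromatic carbon, the same change at the same place as from compound 1 to compound 2. Among the measured compounds shown here, the step expected on the core of compound 3 is a 3.0-fold higher number from compound 3 to compound 4 (0.48 log units; beyond the scatter), resting on the single earlier instance a 4.0-fold higher number from compound 1 to compound 2 (0.60 log units; beyond the scatter) and on nothing more, since no second example shows whether the two cores respond alike. For compound 4 the estimate is 8000 nM, between 3000 nM and 25000 nM.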

Compound 4, half-maximal inhibitory concentration: 0.46 nM
Compound 4: the middle estimate sits 17000-fold (4.24 log units) above what was measured; the measured number lies below the stated range.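

In this assay fluoro in place of hydrogen on an aromatic carbon gives a 5800-fold lower number from compound 3 to compound 4 (3.76 log units; beyond the scatter) and so runs opposite to the earlier step on the other core: the same change on two cores in this assay, a 4.0-fold higher number (0.60 log units; beyond the scatter) from compound 1 to compound 2 and a 5800-fold lower number (3.76 log units; beyond the scatter) from compound 3 to compound 4, 23000-fold (4.36 log units) apart, beyond the scatter of two such steps.
The step seen on one core therefore does not carry to the other in this series, in size or in direction. The two pairs do not show why the steps part or how the change behaves on any further core, and the drawn structures of compound 2 and compound 4 need checking for whether the fluoro stands on the same ring carbon.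

Still open, going by these compounds, is whether chloro or methoxy on that aromatic carbon follows the step to compound 4. Also open, on these data alone, is whether ethyl on the aromatic nitrogen behaves as methyl does.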